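This account rests on a few compounds, and the source may have more. Where it says the series, first, only, none or still open, it means among the compounds named here.

Compound 1, `COc1cc2cc(Oc3ccc(NC(=O)Nc4cccc(C(F)(F)F)c4)cc3)c(C)nc2cc1OC`, is the reference point. In a functional assay on SF-539 cells (Homo sapiens) for inhibition, read by sulforhodamine B assay, with a stated time of 48 h (a lower number here means that less compound is tolerated, a higher number that more compound is tolerated), compound 1 gives 25400 nM. Compound 2, `COc1cc2cc(Oc3ccc(NC(=O)Nc4ccc(Cl)c(C(F)(F)F)c4)cc3)c(C)nc2cc1OC`, carries a chloro group on the same ring. For compound 2 this assay gives only a limit, > 32500 nM, which is the limit of > 32500 nM in this assay, at which 1 of the 2 values shown sits. For the measured compounds named here, the single measured step, an at least 1.2-fold higher number from compound 1 to compound 2 (0.10 log units; that floor lies within the scatter), therefore says only that the number did not fall, and its floor lies within the ordinary scatter of such measurements.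

Compound 3, `COc1cc2cc(Oc3ccc(NC(=O)Nc4ccc(Cl)c(Cl)c4)cc3)c(C)nc2cc1OC`, is the next compound, differing from compound 2 in one place: chloro in place of trifluoromethyl on an aromatic carbon. Going by the values given here, no measured step swaps a trifluoromethyl for a chloro, so the only guide is that the one change made on this ring so far left the number at or above the limit. On that basis compound 3 is expected to stay near compound 2, with an estimated step of a number no higher from compound 2 to compound 3 (the limit leaves the size open) and no direction beyond the scatter. Compound 3 is estimated at 32500 nM, between 14000 nM and 75000 nM.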

Compound 3, concentration lethal to 50% of the cells: 88800 nM
Compound 3: middle estimate off by 2.7-fold (0.44 log units), on the low side; measured number outside the range, above it.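

With both chlorines on the outer phenyl ring, the series now has a step that can be read as a size: a 3.5-fold higher number from compound 1 to compound 3 (0.54 log units; beyond the scatter). So 3,4-dichlorophenyl in place of 3-(trifluoromethyl)phenyl moves the number upward, meaning that more compound is tolerated in this assay. The direct swap of trifluoromethyl for chloro cannot be read, because compound 2 gives only a limit and not a number: the limit of > 32500 nM in this assay, at which 1 of the 3 values shown sits.

The compounds shown leave open how much of the rise from compound 1 comes from the chloro group that compound 2 also carries, and how much from losing trifluoromethyl. They also leave open how an amine or a carboxylic acid in that same place on the ring would read in this assay.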